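A few compounds are considered here, and "the series" means these few. Any claim that something is new, unique, unknown or untested is made for them only; others in the source may bear on it.

Measured compounds and their values:

- Compound 1 `Cc1ccccc1-c1nn(-c2ccc(F)cc2F)cc1CNCCN1CCCCC1`: in an ADME assay on Huh-7 cells (Homo sapiens) for cytotoxicity (on this read-out higher numbers stand for lower toxicity in this test and lower numbers for higher toxicity in this test), compound 1 gives > 20000 nM, which is a limit of the assay rather than a number.
- Compound 2 `Cc1cccc(-c2nn(-c3ccc(F)cc3F)cc2CNCCN2CCN(C)CC2)c1`: in this assay compound 2 gives > 20000 nM, also a limit.
- Compound 3 `Cc1ccccc1-c1nn(-c2ccc(F)c(F)c2)cc1CNCCN1CCN(C)CC1`: in this assay compound 3 gives > 20000 nM, again a limit.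

Compound 1 therefore stands at the limit of > 20000 nM in this assay, at which 3 of the 3 values shown sit. Among the compounds with values here, none of the three compounds has a numeric value, so no ordering among them can be drawn, and no step between two measured compounds that differ in a single place is available to calibrate the change examined here.

The unmeasured compound 4 `Cc1ccccc1-c1nn(-c2ccc(F)cc2F)cc1CNC1CCN(S(C)(=O)=O)CC1` differs from compound 1 in one place: 1-(methylsulfonyl)piperidin-4-yl in place of 2-(piperidin-1-yl)ethyl on an amine nitrogen. With every measured value sitting at the limit, there is no basis for expecting a step of any particular size in this assay; the working expectation is no change beyond the usual scatter, with the result most likely reported again as a limit.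

Compound 4 is thus expected to give 30000 nM in this assay, within a range from 10000 nM to 100000 nM. That expectation amounts to a step that the limit leaves unreadable from compound 1 to compound 4, which is no change beyond the scatter.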

Compound 4, half-maximal cytotoxic concentration: > 20000 nM
Compound 4 was reported as a limit (the forecaster's own chance of this, stated with the estimate: 75%); the middle value is on the limit's open side.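

In this assay, no size can be given for the change from compound 1 to compound 4, because both compounds sit at a limit of the assay rather than at a number: the limit of > 20000 nM in this assay, at which 4 of the 4 values shown sit.

The compounds shown leave open whether 1-(methylsulfonyl)piperidin-4-yl in place of 2-(piperidin-1-yl)ethyl changes the result in this assay at all.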